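Swapping the thiazole for a pyridine in compound 2

The source may hold more compounds than are shown below. What is called first, only, known or untested is meant among the compounds shown, and "the series" means these compounds.

Compound 1 `COCCNc1nc(C)c(-c2nc3ccccc3s2)c(N[C@@H]2C[C@H](CO)[C@@H](O)[C@H]2O)n1` gives 2630 ng.h/mL in an ADME assay on the whole organism (plasma) for pharmacokinetics, with Rattus norvegicus as the target, with a stated time of 6 h, at a dose of 10 mg/kg by the oral route (on this read-out lower numbers stand for lower exposure and higher numbers for higher exposure at the dose given), while compound 2 `Cc1nc(NCc2nccs2)nc(N[C@@H]2C[C@H](CO)[C@@H](O)[C@H]2O)c1-c1nc2ccccc2s1` gives 242 ng.h/mL. The step of an 11-fold lower number from compound 1 to compound 2 (1.04 log units; beyond the scatter) is the only measured one, and compound 2 holds the lower of the two numbers. Compound 3 `Cc1nc(NCc2ccncc2)nc(N[C@@H]2C[C@H](CO)[C@@H](O)[C@H]2O)c1-c1nc2ccccc2s1` differs from compound 2 by pyridin-4-yl in place of 1,3-thiazol-2-yl on a saturated chain carbon bound to a nitrogen on an aromatic ring. That earlier step exchanged the same position but does not involve the present pair, so the direction here is uncertain; compound 3 is expected to move by a 1.2-fold higher number from compound 2 to compound 3 (0.09 log units; within the scatter), within the scatter. Compound 3 is therefore estimated at 300 ng.h/mL, in a range from 80 ng.h/mL to 1200 ng.h/mL.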

Compound 3, area under the concentration-time curve: 47.9 ng.h/mL
The estimate for compound 3 lay 6.3-fold (0.80 log units) above the measured number, outside the stated range (below it).
By their numbers in this assay, from the lowest: compound 3; then compound 2; then compound 1.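

In this assay, the aromatic ring on a saturated chain carbon bound to a nitrogen on an aromatic ring proves not to be interchangeable: pyridin-4-yl in place of 1,3-thiazol-2-yl gives a 5.1-fold lower number from compound 2 to compound 3 (0.70 log units; beyond the scatter) beyond the scatter. Set against methoxymethyl at this place, pyridin-4-yl gives a 55-fold lower number from compound 1 to compound 3 (1.74 log units; beyond the scatter) and so widens the gap that the thiazole opened. Nothing available accounts for either step.

Going by these compounds, whether a dimethylamino group or a longer ether chain at this place would match methoxymethyl remains open. So does whether pyridin-2-yl would behave like pyridin-4-yl.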